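The source may hold more compounds than are shown below. What is called first, only, known or untested is meant among the compounds shown, and "the series" means these compounds.

Measured compounds:
- compound 1, `CCNC(=O)c1cc(Oc2ccc(NC(=O)c3nn(-c4cccc(F)c4)c(=O)cc3C)cc2)ccn1`, 7410 nM
- compound 2, `CNC(=O)c1cc(Oc2ccc(NC(=O)c3nn(-c4ccccc4Cl)c(=O)cc3C)cc2F)ccn1`, 11800 nM
- compound 3, `CCCNC(=O)c1cc(Oc2ccc(NC(=O)c3nn(-c4ccc(Br)cc4F)c(=O)cc3C)cc2F)ccn1`, 235000 nM

In a functional assay on A549 cells (Homo sapiens) for antiproliferative activity, read by MTT assay, with a stated time of 72 h (a higher number here means a weaker inhibitor, a lower number a stronger inhibitor), compound 1 gives 7410 nM, the lowest of the three numbers. Compound 2 sits within the usual scatter of compound 1, so no order between the two can be read. Compound 3 lies far beyond the scatter from compound 1, by a wide margin.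

Compound 4, `CCNC(=O)c1cc(Oc2ccc(NC(=O)c3nn(-c4cccc(C(F)(F)F)c4)c(=O)cc3C)cc2)ccn1`, has not been measured in this assay. Its difference from compound 1 is trifluoromethyl in place of fluoro on an aromatic carbon. Going by the values given here, no measured pair shares this change, so nothing in the data fixes its size. Compound 4 is expected to land near compound 1, with a step of a 1.1-fold lower number from compound 1 to compound 4 (0.06 log units; within the scatter) that is expected to stay within the scatter, in either direction. For compound 4 the expected value in this assay is 6500 nM, with a range from 2500 nM to 18000 nM, the width reflecting the absence of any comparable step among the measured compounds.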

Compound 4, half-maximal inhibitory concentration: 10000 nM
Compound 4: the middle estimate sits 1.5-fold (0.19 log units) below what was measured; measured number inside the range.
By their numbers in this assay, from the lowest: compounds 1, 4 and 2 (each within the scatter of the next); then compound 3.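

In this assay the change from 3-fluorophenyl to 3-(trifluoromethyl)phenyl gives a 1.3-fold higher number from compound 1 to compound 4 (0.13 log units; within the scatter) as the only step among these compounds that isolates a single place. On this aromatic carbon, meta to a large group, trifluoromethyl in place of fluoro therefore leaves no readable difference on the ethyl amide background of compound 1. No measured data bear on the reason for this result.

From the compounds shown here alone, whether this position separates compounds at all stays open: a carboxylic acid, an amine or a methoxy group here would test it with groups that carry no fluorine. Also open, going by these compounds, is whether the same change reads alike on the methyl amide of compound 2 or the propyl amide of compound 3, which both differ from compound 1 in several places.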